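Acylguanidine series: aryl variation in the sodium/hydrogen exchanger assay

This account rests on a few compounds, and the source may have more. Where it says the series, first, only, none or still open, it means among the compounds named here.

Measured so far:
compound 1 `Cc1c(C(=O)N=C(N)N)ccc(Cl)c1S(C)(=O)=O` — 1300 nM
compound 2 `CCCCCc1cc(C)c(C(=O)N=C(N)N)cc1S(C)(=O)=O` — 27 nM

In a functional assay for inhibition of sodium/hydrogen exchanger (Oryctolagus cuniculus) (on this read-out lower numbers stand for stronger inhibition and higher numbers for weaker inhibition), compound 2 gives the lowest of the two numbers recorded; the nearest is compound 1, whose number is higher by a margin beyond the usual scatter. Compound 3 `Cc1cc(Sc2ccc(Cl)cc2)c(S(C)(=O)=O)cc1C(=O)N=C(N)N` has not yet been measured in this assay. It differs from compound 2 by (4-chlorophenyl)sulfanyl in place of pentyl on an aromatic carbon.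

Within the data shown here, no step between measured compounds describes this kind of exchange, so the expectation rests on compound 2 alone. The change is expected to cost some potency in this assay, a step of moderate size toward a higher number, though it could also fall within the scatter. The step from compound 2 to compound 3 is estimated at a 2.6-fold higher number from compound 2 to compound 3 (0.41 log units; beyond the scatter). For compound 3 the estimate in this assay is 70 nM, within a range from 15 nM to 350 nM.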

Compound 3, half-maximal inhibitory concentration: 19 nM
Compound 3: the middle estimate sits 3.7-fold (0.57 log units) above what was measured; low and high end bracket the measured number.
By their numbers in this assay, from the lowest: compounds 3 and 2 (each within the scatter of the next); then compound 1.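

In this assay, (4-chlorophenyl)sulfanyl in place of pentyl on the aromatic carbon ortho to the methylsulfonyl group gives a 1.4-fold lower number from compound 2 to compound 3 (0.15 log units; within the scatter) and does not separate the two groups on this read-out. This position therefore carries either an open pentyl chain with no ring or a larger group with a six-membered aromatic ring, a sulfur and a chlorine, and the numbers stay within the scatter of each other. No measurement on hand bears on why the two groups read alike.

Still open, going by these compounds, is how much the sulfur link and the chlorine each contribute, which phenylsulfanyl or phenoxy at this carbon would address. A cyclic amine such as piperidine, or a carboxylic acid, at the same carbon also remains to be placed against compound 2 and compound 3.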